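Inverting one ring stereocentre in a bradykinin B1 sulfonamide

The source may report more compounds than this note shows. Statements on the series, on what has been measured and on what is new or still open speak of the compounds shown alone.

Of the compounds shown here, two have been measured in an assay on HEK293 cells for displacement of a labelled ligand from B1 bradykinin receptor (Homo sapiens), read by scintillation counting; on this read-out higher numbers stand for weaker inhibition and lower numbers for stronger inhibition. Compound 1 `COc1cc(C)c(S(=O)(=O)N(C)CCOCC(=O)N2CCN([C@@H]3CN4CCC3CC4)CC2)c(C)c1` gives 5.6 nM in this assay, the higher of the two numbers shown. Compound 2 `CN(Cc1ccc(C2=NCCN2)cc1)C(=O)COCCN(C)S(=O)(=O)c1c(Cl)cccc1Cl` gives 4.2 nM in this assay, a difference from compound 1 that lies within the usual scatter, so the two stand together rather than apart.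

Compound 3 `COc1cc(C)c(S(=O)(=O)N(C)CCOCC(=O)N2CCN([C@H]3CN4CCC3CC4)CC2)c(C)c1` has not yet been measured. It differs from compound 1 only in configuration: the two compounds have the same atoms and bonds; at least one stereo element is drawn with a configuration in one of them and without one in the other: 1 of 3 stereo elements differ; a stereocentre at a saturated ring carbon is drawn S in compound 1 and R in compound 3. Among the compounds with values here, no measured pair in this set shows what such an inversion does in this assay, so there is no step to lean on. The account therefore rests on the structure alone. Compound 1 at 5.6 nM is already a strong inhibitor, and it is expected that the inverted stereocentre in compound 3 will give a higher number in this assay, estimated as a step of an 11-fold higher number from compound 1 to compound 3 (1.03 log units; beyond the scatter) beyond the scatter. Compound 3 is thus expected to come in at 60 nM, with a range from 6 nM to 700 nM.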

Compound 3, inhibition constant: 34 nM
Estimate against measurement, compound 3: 1.8-fold (0.25 log units) above, within the range that was stated.
By their numbers in this assay, from the lowest: compounds 2 and 1 (each within the scatter of the next); then compound 3.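

The inversion at this saturated ring carbon is not silent: in this assay, the change from S to R gives a 6.1-fold higher number from compound 1 to compound 3 (0.78 log units; beyond the scatter). Within the data shown here, the earlier compounds offered no single-place step, so this is the first sign that the position responds to configuration alone, with no atom or bond altered, and that the S form drawn in compound 1 gives the stronger inhibition of the two. The loss is only partial, since compound 3 still gives 34 nM, so the R configuration weakens inhibition without abolishing it, and all that the two structures offer to account for the step is this: the fact that one of compounds 1 and 3 is drawn with a defined configuration and the other without, at the place where they differ

The compounds shown leave open whether this preference for one configuration depends on the rest of the shared core, or would persist with a different sulfonamide aryl group, such as one carrying chlorine in place of the methoxy group. They also leave open how either form would compare with an open-chain dimethylamino group, which carries no stereocentre, in place of the group that holds this ring carbon.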